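A Methoxy Added Where Every Value So Far Agrees

The source may hold more compounds than are shown below. What is called first, only, known or untested is meant among the compounds shown, and "the series" means these compounds.

Three measured compounds share one core: compound 1 `COc1ccc(-c2cc(/C=C/C(=O)c3ccc(N)cc3)[nH]n2)cc1`, compound 2 `COc1ccc(C(=O)/C=C/c2cc(-c3cc(OC)c(OC)c(OC)c3)n[nH]2)cc1OC` and compound 3 `COc1cc(-c2cc(/C=C/C(=O)c3ccc(F)c(F)c3)[nH]n2)cc(OC)c1OC`. In a functional assay on SN12C cells (Homo sapiens) for cytotoxicity, read by sulforhodamine B assay, with a stated time of 48 h, tested at 0.1 uM (a lower number here means a stronger effect, a higher number a weaker effect of the compound at the concentration tested), compound 1 gives 94%, compound 2 gives 94% and compound 3 gives 94%, so compound 1 stands level with both within the scatter. Among the measured compounds shown here, the single measured step, no change at the digits printed from compound 2 to compound 3 (within the scatter), places 3,4-difluorophenyl in place of 3,4-dimethoxyphenyl on a carbonyl carbon and leaves the read-out unmoved. Compound 4 `COc1ccc(-c2cc(/C=C/C(=O)c3ccc(N)cc3)[nH]n2)cc1OC` differs from compound 1 by methoxy in place of hydrogen on an aromatic carbon. For the measured compounds named here, no measured step touches this position, but all three values sit at the same weak level, so the change is expected to be no change at the digits printed from compound 1 to compound 4 (within the scatter), nothing beyond the scatter. Compound 4 is therefore estimated at 94%, with a range from 82% to 104%.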

Compound 4, a percentage reported as activity, at one concentration (the size of the read-out at that concentration, not a potency): 99%
Compound 4: middle estimate off by 5 percentage points, on the low side, and the stated range covers the measured number.
By their numbers in this assay, from the lowest: compounds 1, 2, 3 and 4 (each within the scatter of the next).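

In this assay, among the compounds shown here, the step of a number 5 percentage points higher from compound 1 to compound 4 (within the scatter) is the first reading at this place, on the aromatic carbon ortho to a methoxy group and meta to a large group. The earlier step touched only the group on the carbonyl carbon, whereas this one shows that adding methoxy to the other ring also stays within the scatter. The compounds shown leave open whether a hydroxyl, a chlorine or a longer ethoxy chain on the same carbon would read any differently. Nothing available explains the result.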